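Bromo for Phenyl on the Ketone Aryl Group

A few compounds are considered here, and "the series" means these few. Any claim that something is new, unique, unknown or untested is made for them only; others in the source may bear on it.

Of the compounds shown here, three sharing one core have been measured in a functional assay on PC-3 cells (Homo sapiens) for cytotoxicity, read by MTT assay, with a stated time of 48 h; a lower number here means a stronger inhibitor, a higher number a weaker inhibitor. Compound 3 `COc1cc(-c2nnc3n2NC(c2ccco2)C(C(=O)c2ccc(-c4ccccc4)cc2)S3)cc(OC)c1OC` gives 45900 nM. Compound 1 `COc1cc(-c2nnc3n2NC(c2ccco2)C(C(=O)c2ccc(F)c(F)c2)S3)cc(OC)c1OC` gives 36000 nM, and compound 2 `COc1cc(-c2nnc3n2NC(c2ccco2)C(C(=O)C2CC2)S3)cc(OC)c1OC` gives 95200 nM, so compound 3 sits second highest of the three, with compound 1 within the scatter of it and compound 2 beyond it. Compound 4 `COc1cc(-c2nnc3n2NC(c2ccco2)C(C(=O)c2ccc(Br)cc2)S3)cc(OC)c1OC` differs from compound 3 by bromo in place of phenyl on an aromatic carbon. The comparisons that bear on this all change the group on the carbonyl carbon: a 1.3-fold higher number from compound 1 to compound 3 (0.11 log units; within the scatter), while a 2.1-fold lower number from compound 2 to compound 3 (0.32 log units; beyond the scatter). Exchanging one aromatic group for another thus moved the number little, and only compound 2, with cyclopropyl, stood apart. A similarly small step is expected for a 1.1-fold lower number from compound 3 to compound 4 (0.06 log units; within the scatter). Compound 4 is therefore estimated at 40000 nM, with a range from 20000 nM to 80000 nM.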

Compound 4, half-maximal inhibitory concentration: 36400 nM
Compound 4: middle estimate off by 1.1-fold (0.04 log units), on the high side, within the range that was stated.
By their numbers in this assay, from the lowest: compounds 1, 4 and 3 (each within the scatter of the next); then compound 2.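

The outer phenyl ring is not needed to hold the number at this level: a lone bromo in its place stays within the scatter (a 1.3-fold lower number from compound 3 to compound 4 (0.10 log units; within the scatter)). The 4-bromophenyl group also matches 3,4-difluorophenyl (a 1.0-fold higher number from compound 1 to compound 4 (0.00 log units; within the scatter)), and it stands clear of cyclopropyl (a 2.6-fold lower number from compound 2 to compound 4 (0.42 log units; beyond the scatter)), so all three aromatic groups now sit together, with compound 2 alone apart. No available evidence explains this. Still open, on these data alone, is whether an amine or a carboxylic acid in place of the bromo, or a longer chain in place of the whole aromatic group, would move the number beyond the scatter.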